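Trimming the group on the carbonyl carbon

The compounds below may be only part of what the source reports. "The series", "measured", "known", "first", "only" and "open" are said of these compounds alone.

Measured so far in a functional assay on BaF3 cells (Mus musculus) for antiproliferative activity, read by CCK-8 assay and cell counting, with a stated time of 76 h (a lower number here means a stronger inhibitor, a higher number a weaker inhibitor), for three compounds:
- Compound 1 `COc1cc2nccc(Oc3ccc(Nc4nn(C)cc4C(=O)NCc4ccccc4)cc3)c2cc1C(N)=O` (> 10000 nM)
- Compound 2 `COc1cc2nccc(Oc3ccc(Nc4nn(C)cc4C(=O)NC4CCCCCCC4)cc3)c2cc1C(N)=O` (3210 nM)
- Compound 3 `COc1cc2nccc(Oc3ccc(Nc4nn(C)cc4C(=O)N4CCCC5CCCCC54)cc3)c2cc1C(N)=O` (4330 nM)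

The value of compound 1 (> 10000 nM) is a limit and not a number. Compound 3 (4330 nM) lies within the scatter of compound 2 (3210 nM) and so stands level with it. Compound 4 `COc1cc2nccc(Oc3ccc(Nc4nn(C)cc4C(=O)NCC(C)C)cc3)c2cc1C(N)=O` differs from compound 3 by a group of 5 heavy atoms (4 carbon, 1 nitrogen; no ring) in place of a group of 10 heavy atoms (9 carbon, 1 nitrogen; one six-membered non-aromatic ring of carbon only, one six-membered non-aromatic ring with 1 hetero atom), on a carbonyl carbon in this same place.

Three measured steps changed this group: an at least 3.1-fold lower number from compound 1 to compound 2 (0.49 log units; beyond the scatter) and an at least 2.3-fold lower number from compound 1 to compound 3 (0.36 log units; beyond the scatter) and a 1.3-fold higher number from compound 2 to compound 3 (0.13 log units; within the scatter) on the same carbonyl carbon. The first two were modest and the third stayed within the scatter, so only a small rise is expected in this assay here. The expected step is a 1.4-fold higher number from compound 3 to compound 4 (0.14 log units; within the scatter) and it is not expected to pass beyond the scatter. Compound 4 is estimated at 6000 nM (expected range 2000 nM to 18000 nM).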

Compound 4, half-maximal inhibitory concentration: > 10000 nM
Compound 4 ended at the assay's limit; the forecaster's own chance of this, stated with the estimate: 35%; at least 1.6-fold (0.22 log units) between middle value and limit.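

In this assay, isobutylamino on this carbonyl carbon does worse than either ring-bearing group: an at least 2.3-fold higher number from compound 3 to compound 4 (0.36 log units; beyond the scatter) and an at least 3.1-fold higher number from compound 2 to compound 4 (0.49 log units; beyond the scatter). Among the compounds shown, only the non-aromatic ring groups of compound 2 and compound 3 give readable numbers, while the open chain of compound 4 joins the benzyl of compound 1 at the limit, so the step between those two cannot be read: the limit of > 10000 nM in this assay, at which 2 of the 4 values shown sit.

Open, on these data alone, is whether the ring itself or simply the number of heavy atoms matters here. A cyclopentyl group or a longer chain such as octyl could separate the two.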